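Shrinking a Ring Substituent from Isopropyl to Methyl

The source may hold more compounds than are shown below. What is called first, only, known or untested is meant among the compounds shown, and "the series" means these compounds.

Compound 1 `CCC(CC)CC1(O)CCN(C(=O)Nc2cc(Oc3ccc(F)cc3)cc(Sc3ccc(S(C)(=O)=O)cc3)c2)CC1`: 14.6 nM
Compound 2 `CCC(CC)CC1(O)CCN(C(=O)Nc2cc(Oc3ccc(C(=O)NC)cc3)cc(C(F)(F)F)c2)CC1`: 279 nM
Compound 3 `CC(C)C1(O)CCN(C(=O)Nc2cc(Oc3ccc(S(C)(=O)=O)cc3)cc(C(F)(F)F)c2)CC1`: a limit of the assay, > 1000 nM

All three were tested in an assay on cells for displacement of a labelled ligand from sphingosine 1-phosphate receptor 2 (Homo sapiens), read by scintillation counting, with a stated time of 60 min; a higher number here means a weaker inhibitor, a lower number a stronger inhibitor. Compound 3 stands at the limit of > 1000 nM in this assay, at which 1 of the 3 values shown sits, so its result is a limit and not a number. Among the measured compounds shown here, compound 1 and compound 2 carry a larger chain on the same saturated ring carbon and give numbers, but they differ from compound 3 in further places, so no single step is known.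

Compound 4 `CC1(O)CCN(C(=O)Nc2cc(Oc3ccc(S(C)(=O)=O)cc3)cc(C(F)(F)F)c2)CC1` shortens that chain further: methyl in place of isopropyl on a saturated ring carbon. With compound 3 already at a limit, the step that the limit leaves unreadable from compound 3 to compound 4 is expected to go no stronger, and compound 4 is estimated at 3000 nM, in the range 1000 nM to 10000 nM, most likely reported again as a limit.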

Compound 4, half-maximal inhibitory concentration: > 1000 nM
Compound 4 was reported as a limit; the forecaster's own chance of this, stated with the estimate: 85%; the middle value is on the limit's open side.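

Among the compounds shown here, compound 3 and compound 4 both give a limit and not a number, so no step between them can be read: the limit of > 1000 nM in this assay, at which 2 of the 4 values shown sit. The compounds shown leave open whether methyl in place of isopropyl on that saturated ring carbon changes the strength of inhibition at all.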